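This account rests on a few compounds, and the source may have more. Where it says the series, first, only, none or still open, it means among the compounds named here.

Compound 1 `Cc1ccc(SCc2ccc(C(=O)Nc3ccccc3N)cc2)cc1` gives 84%
Compound 2 `Nc1ccccc1NC(=O)/C=C/c1ccc(CSc2cccc3ccccc23)cc1` gives 35.2%
Compound 3 `Nc1ccccc1NC(=O)c1ccc(CSc2ccc(C(F)(F)F)cn2)cc1` gives 25.8%

Compound 1 stands highest of the three in a functional assay on HCT-116 cells (Homo sapiens) for inhibition, read by CCK-8 assay, with a stated time of 72 h, tested at 8 uM (a lower number here means less inhibition of growth, a higher number more inhibition of growth at the concentration tested), and lies beyond the scatter above both compound 2 and compound 3. Compound 4 `Cc1cc(C)cc(SCc2ccc(C(=O)Nc3ccccc3N)cc2)c1` keeps the core of compound 1 but carries 3,5-dimethylphenyl in place of 4-methylphenyl on a sulfur. Going by the values given here, no two measured compounds differ in one place only, so the data offer no direct measure of such a change. A slight fall in this assay is expected, most likely none beyond the scatter, although a larger fall cannot be excluded. The estimated step is a number 6 percentage points lower from compound 1 to compound 4 (within the scatter) and remains an expectation. Compound 4 is estimated at 78% (range 55% to 94%).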

Compound 4, percent growth inhibition at one concentration: 72.9%
The estimate for compound 4 lay 5.1 percentage points above the measured number; the range from low to high includes it.
By their numbers in this assay, from the lowest: compounds 3 and 2 (each within the scatter of the next); then compound 4; then compound 1.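

Going by these compounds alone, exchanging 4-methylphenyl for 3,5-dimethylphenyl on the sulfur gives the first direct reading at this position in this assay: a number 11.1 percentage points lower from compound 1 to compound 4 (beyond the scatter). The loss is modest but real, so this position responds even to a change as small as this one, and compound 4 still gives 72.9%. No measurement at hand accounts for this step.

The compounds shown leave open how a chlorine atom or a methoxy group in place of the methyl groups would read. They also leave open how an unsubstituted phenyl on the sulfur would compare.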